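Bromo in place of cyano: compound 3 to compound 4

A few compounds are considered here, and "the series" means these few. Any claim that something is new, unique, unknown or untested is made for them only; others in the source may bear on it.

Measured so far in a functional assay on CHO cells for inhibition of Orexin/Hypocretin receptor type 1 (Homo sapiens), read by FLIPR and calcium flux; on this read-out lower numbers stand for stronger inhibition and higher numbers for weaker inhibition:
compound 1 `CCN(C(=O)CN(c1cc(N(C)C)ccc1Cl)S(=O)(=O)c1ccc(OC)c(OC)c1)c1cnc(C)cn1`: 5 nM
compound 2 `CCN(C(=O)CN(c1cc(N(C)C)ccc1Cl)S(=O)(=O)c1ccc(OC)c(OC)c1)c1cccc(C)n1`: 17 nM
compound 3 `CCN(CC)C(=O)CN(c1ccc(C)cc1)S(=O)(=O)c1ccc(C#N)cc1`: > 10000 nM

Compound 3 stands apart from the other two: its read-out is a limit of the assay, not a number. Going by the values given here, compound 3 is the one value sitting at the limit of > 10000 nM in this assay, at which 1 of the 3 values shown sits. Among the compounds with values here, the only measured step, a 3.4-fold higher number from compound 1 to compound 2 (0.53 log units; beyond the scatter), concerns a group on an amide-type nitrogen in a different part of the structure, so no measured step bears on the change to compound 4 `CCN(CC)C(=O)CN(c1ccc(C)cc1)S(=O)(=O)c1ccc(Br)cc1`. That change is bromo in place of cyano on an aromatic carbon. With nothing on record to move the number off the limit, compound 4 is expected at 10000 nM, in the range 3000 nM to 30000 nM. The expected step is a number no higher from compound 3 to compound 4 (the limit leaves the size open), and the assay may well report only a limit.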

Compound 4, half-maximal inhibitory concentration: > 10000 nM
Compound 4 gave a limit, no number; the forecaster's own chance of this, stated with the estimate: 70%; the middle value lies on the limit itself.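

Compound 3 and compound 4 both stand at a limit in this assay, so no step can be read for bromo in place of cyano: the limit of > 10000 nM in this assay, at which 2 of the 4 values shown sit.

The compounds shown leave open how far cyano and bromo differ on this read-out.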